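This account rests on a few compounds, and the source may have more. Where it says the series, first, only, none or still open, it means among the compounds named here.

Measured so far in an assay on isolated protein for inhibition of Hematopoietic prostaglandin D synthase (Homo sapiens), read by fluorescence polarization; a higher number here means a weaker inhibitor, a lower number a stronger inhibitor:
compound 1, `c1nc(NC2CCCC2)c2cn[nH]c2n1`: 8500 nM
compound 2, `c1cncc(-c2c[nH]nc2C2CC2)c1`: 17000 nM
compound 3, `CCNC(=O)N1Cc2cc(-c3c[nH]nc3C3CC3)cnc2C1`: 40 nM

Compound 3 holds the lowest number of the three in this assay. Compound 1 lies well above it and compound 2 higher still; both separations are beyond the scatter, so compound 3 is the strongest inhibitor of the measured set.

Compound 4, `O=C(NC1CCCC1)N1Cc2cc(-c3c[nH]nc3C3CC3)cnc2C1`, has not yet been measured. It differs from compound 3 in one place: cyclopentyl in place of ethyl on an amide-type nitrogen. Among the measured compounds shown here, no measured pair shows the effect of this change on this core, so no step size can be read from the data. Compound 1 also carries a cyclopentylamino group, but on a different core, and its value alone cannot be set against this single change. The expectation for compound 4 is a step of no size beyond the scatter, no change at the digits printed from compound 3 to compound 4 (within the scatter), in either direction. Compound 4 is estimated at 40 nM, with a range from 10 nM to 160 nM.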

Compound 4, half-maximal inhibitory concentration: < 10 nM
Compound 4 was reported as a limit; the forecaster's own chance of this, stated with the estimate: 2%; middle value at least 4.0-fold (0.60 log units) from the limit.
By their numbers in this assay, from the lowest: compound 3; then compounds 1 and 2 (each within the scatter of the next). At a limit, below all of these: compound 4.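

In this assay compound 4 is reported at a limit, < 10 nM. Cyclopentyl in place of ethyl on an amide-type nitrogen gives an at least 4.0-fold lower number from compound 3 to compound 4 (0.60 log units; beyond the scatter), the first step in this series read at a single place, and it shows that the number responds to the group carried on this nitrogen and that the ring of carbon only is accepted there. That step is a bound, and its full size cannot be read past the limit: the limit of < 10 nM in this assay, at which 1 of the 4 values shown sits.

Open, going by these compounds, is whether the ring itself or only the carbon count carries the step; a straight pentyl chain on the same nitrogen would separate the two. Also open, on these data alone, is the response to a ring holding an atom other than carbon, such as tetrahydropyranyl or piperidinyl, at this place.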